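The source may hold more compounds than are shown below. What is called first, only, known or untested is meant among the compounds shown, and "the series" means these compounds.

Measured so far in a functional assay on aorta (Rattus norvegicus, strain Wistar) for inhibition, with a stated time of 60 min; a higher number here means a larger maximal response, a lower number a smaller maximal response:
Compound 1 `Oc1ccc(-c2nc3cc(C(F)(F)F)ccc3[nH]2)cc1` gives 37%.
Compound 2 `O=[N+]([O-])c1ccccc1-c1nc2cc(C(F)(F)F)ccc2[nH]1` gives 85.3%.
Compound 3 `CC(C)Oc1ccccc1-c1nc2cc([N+](=O)[O-])ccc2[nH]1` gives 31.7%.

Compound 2 stands highest of the three numbers; compound 1 sits well below it, beyond the scatter, and compound 3 sits further below still, also beyond the scatter. The two lower compounds lie close to each other.

Compound 4 `CCOc1ccccc1-c1nc2cc(C(F)(F)F)ccc2[nH]1` has not yet been measured in this assay. It differs from compound 2 in one place: ethoxy in place of nitro on an aromatic carbon.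

Within the data shown here, no step between two measured compounds matches this change, so the size of its effect is not known from the set. What the numbers do show is that only compound 2 reaches a high maximal response, while compound 1 and compound 3 stay low. On that basis the step of a number 40.3 percentage points lower from compound 2 to compound 4 (beyond the scatter) is expected to go downward, beyond the scatter, toward the range of the other two measured compounds. Among the measured compounds shown here, compound 4 is estimated at 45%, with a range from 25% to 75%; the width reflects that no measured step mirrors this change.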

Compound 4, largest response reached (Emax), in percent of the reference or control that the assay uses: 19.8%
Compound 4: middle estimate off by 25.2 percentage points, on the high side, and the stated range ends above it.
By their numbers in this assay, from the lowest: compound 4; then compounds 3 and 1 (each within the scatter of the next); then compound 2.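

In this assay, among these compounds, the first single-place step, ethoxy in place of nitro on an aromatic carbon ortho to a large group, is a number 65.5 percentage points lower from compound 2 to compound 4 (beyond the scatter) with the rest of the structure unchanged. The maximal response therefore depends strongly on which group occupies this position, and the large step arises even though the leaving and entering groups have the same number of heavy atoms. Nothing measured here accounts for the size of this step.

The compounds shown leave open how an amine or a carboxylic acid at this position would compare with nitro and ethoxy, and whether a longer alkoxy chain would behave like ethoxy. Also open, on these data alone, is whether the same exchange would produce a step of similar size on a core carrying nitro in place of trifluoromethyl.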